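Adding a side chain to compound 2

The compounds below may be only part of what the source reports. "The series", "measured", "known", "first", "only" and "open" are said of these compounds alone.

Values in an ADME assay on HepG2 cells (Homo sapiens) for cytotoxicity, read by MTT assay, with a stated time of 48 h; on this read-out lower numbers stand for stronger inhibition and higher numbers for weaker inhibition:
- compound 1 `CC(=O)NC[C@H]1CN(c2ccc(-c3ccc(/C=C4\SC(=S)NC4=O)cc3)c(F)c2)C(=O)O1`: 63900 nM
- compound 2 `CC(=O)NC[C@H]1CN(c2ccc(-c3ccc(/C=C4\NC(=S)NC4=O)cc3)c(F)c2)C(=O)O1`: 61700 nM

Compound 2 cannot be separated from compound 1 on these numbers, with a 1.0-fold lower number from compound 1 to compound 2 (0.02 log units; within the scatter). Compound 3 `CCN(CC)CCCN1C(=O)/C(=C/c2ccc(-c3ccc(N4C[C@H](CNC(C)=O)OC4=O)cc3F)cc2)NC1=S` differs from compound 2 by 3-(diethylamino)propyl in place of hydrogen on an amide-type nitrogen in a ring. Among the compounds with values here, the one measured step, a 1.0-fold lower number from compound 1 to compound 2 (0.02 log units; within the scatter), is a ring exchange and only loosely bears on this change. Within the data shown here, no measured step covers substitution at this nitrogen, so confidence is low. A moderate shift toward stronger inhibition in this assay is expected, with an estimated 2.1-fold lower number from compound 2 to compound 3 (0.31 log units; beyond the scatter). The estimate for compound 3 is 30000 nM, with an expected range of 10000 nM to 70000 nM.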

Compound 3, half-maximal inhibitory concentration: 91000 nM
Compound 3: the middle estimate sits 3.0-fold (0.48 log units) below what was measured, outside the stated range (above it).
By their numbers in this assay, from the lowest: compounds 2, 1 and 3 (each within the scatter of the next).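

Substitution on the amide-type nitrogen in the ring now has a measured result: in this assay, 3-(diethylamino)propyl in place of hydrogen gives a 1.5-fold higher number from compound 2 to compound 3 (0.17 log units; within the scatter). Within the data shown here, the earlier compounds varied only the five-membered ring, so this is the first sign that this nitrogen can carry a chain of this kind without a read-out change beyond the scatter. No available evidence accounts for this result.

Still open, going by these compounds, is whether a shorter alkyl chain, a morpholine or a carboxylic acid at this nitrogen would give a step beyond the scatter.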